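A few compounds are considered here, and "the series" means these few. Any claim that something is new, unique, unknown or untested is made for them only; others in the source may bear on it.

Working notes on the cinnamate series.

Compound 1 `COc1ccc([C@@H](O)COC(=O)/C=C/c2ccccc2)cc1OC` is the reference point; in an ADME assay on Vero cells (Chlorocebus sabaeus) for cytotoxicity, read by MTT assay, with a stated time of 72 h (a higher number here means that more compound is tolerated, a lower number that less compound is tolerated), compound 1 gives 5870 nM. Compound 2 `COc1cc([C@@H](O)COC(=O)/C=C/c2ccccc2)cc(OC)c1OC` carries one more substituent on the aromatic ring, the change being (methoxy in place of hydrogen on an aromatic carbon); in this assay compound 2 gives 122000 nM, and the step is a 21-fold higher number from compound 1 to compound 2 (1.32 log units; beyond the scatter).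

Compound 3 `COc1cccc([C@H](O)COC(=O)/C=C/c2ccccc2)c1` rests on a different core; the difference between the cores of compound 1 and compound 3 is not broken down here. In this assay compound 3 gives 61900 nM, which is within the scatter of compound 2 and beyond it against compound 1.

Compound 4 `COc1cccc([C@H](O)COC(=O)/C=C/c2ccccc2)c1OC` is not yet measured. It differs from compound 3 by methoxy in place of hydrogen on an aromatic carbon. This is the same kind of change as from compound 1 to compound 2, not the same: there the entering group sat ortho to a methoxy group, meta to a large group and meta to a methoxy group, here it sits ortho to a large group and ortho to a methoxy group.

The earlier step was large; because a 21-fold higher number from compound 1 to compound 2 (1.32 log units; beyond the scatter) went up and compound 3 already stands high, a smaller upward step is expected, a 2.1-fold higher number from compound 3 to compound 4 (0.32 log units; beyond the scatter). Compound 4 is estimated at 130000 nM, with a range from 40000 nM to 400000 nM.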

Compound 4, half-maximal cytotoxic concentration: 28400 nM
Estimate against measurement, compound 4: 4.6-fold (0.66 log units) above; the measured number lies below the stated range.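

In this assay, methoxy in place of hydrogen on an aromatic carbon now gives a 2.2-fold lower number from compound 3 to compound 4 (0.34 log units; beyond the scatter). Set beside the earlier step, the same change does not carry over between the two cores in either size or direction: the same change on two cores in this assay, a 21-fold higher number (1.32 log units; beyond the scatter) from compound 1 to compound 2 and a 2.2-fold lower number (0.34 log units; beyond the scatter) from compound 3 to compound 4, 45-fold (1.66 log units) apart, beyond the scatter of two such steps

This shows that, for compounds 1 to 4, the result of this change on one core cannot be read across to the other. It does not show what separates the two steps: the cores differ, the entering group in compound 4 sits ortho to a large group and ortho to a methoxy group unlike in compound 2, and each result rests on a single pair.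

Open, going by these compounds, is whether the core or the place of the entering group decides the outcome, which a methoxy placed elsewhere on the core of compound 3 could help to separate. Also open, on these data alone, is how a different group at the same place, such as an ethoxy, a fluorine or an amine, would read in this assay.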